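The source may report more compounds than this note shows. Statements on the series, on what has been measured and on what is new or still open speak of the compounds shown alone.

Measured in a functional assay on Ramos cells (Homo sapiens) for cytotoxicity, read by CCK-8 assay, with a stated time of 72 h; on this read-out higher numbers stand for weaker inhibition and lower numbers for stronger inhibition:
- Compound 1 `Cn1cc(NC(=O)c2cnc3ccc(N[C@@H]4CCCNC4)nn23)c(C(F)F)n1`: 11400 nM
- Compound 2 `Cn1cc(NC(=O)c2cnc3ccc(N[C@@H]4CCNC4)nn23)c(C(F)F)n1`: 45000 nM
- Compound 3 `Cn1cc(NC(=O)c2cnc3ccc(N[C@@H]4CCCNC4)nn23)c(C(F)(F)F)n1`: > 50000 nM, a limit

Compound 3 has no number on this read-out, and its entry is only a limit. Compound 4 `Cn1cc(NC(=O)c2cnc3ccc(N[C@@H]4CCCNC4)nn23)c(C#N)n1` carries cyano in place of trifluoromethyl on an aromatic carbon. Within the data shown here, no measured compound carries cyano, so the evidence is indirect. The step that touches this same group is an at least 4.3-fold higher number from compound 1 to compound 3 (0.64 log units; beyond the scatter). The other step, a 3.9-fold higher number from compound 1 to compound 2 (0.60 log units; beyond the scatter), lies elsewhere in the molecule and serves only as a gauge of size, since compound 4 keeps the piperidin-3-yl. A modest step towards lower numbers is therefore expected in this assay, although compound 4 may also end at the limit. The expected change is an at least 2.2-fold lower number from compound 3 to compound 4 (0.35 log units; beyond the scatter). The estimate for compound 4 is 22000 nM. The expected range for compound 4 runs from 7000 nM to 50000 nM.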

Compound 4, half-maximal inhibitory concentration: 28800 nM
The estimate for compound 4 lay 1.3-fold (0.12 log units) below the measured number; the range from low to high includes it.
By their numbers in this assay, from the lowest: compound 1; then compounds 4 and 2 (each within the scatter of the next). At a limit, above all of these: compound 3.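

At this aromatic carbon, cyano in place of trifluoromethyl gives a measured number in this assay, where the trifluoromethyl compound had reached only a limit, with an at least 1.7-fold lower number from compound 3 to compound 4 (0.23 log units; that floor lies within the scatter). Cyano does not match difluoromethyl, however, with a 2.5-fold higher number from compound 1 to compound 4 (0.40 log units; beyond the scatter), so among the three groups shown at this carbon, difluoromethyl gives the lowest number. The entry for compound 3 is a limit, so the step away from it is known only as a floor, and its true size cannot be read: the limit of > 50000 nM in this assay, at which 1 of the 4 values shown sits.

From the compounds shown here alone, what a methyl group or a carboxamide would give at this carbon remains open. Going by these compounds, it is also open whether cyano at this carbon would shift the number in the same way when paired with the pyrrolidin-3-yl of compound 2.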